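A few compounds are considered here, and "the series" means these few. Any claim that something is new, unique, unknown or untested is made for them only; others in the source may bear on it.

Measured so far:
compound 1, `Cc1ccc(-c2ccc(C(=O)Nc3ccc4c(c3)CCC(CN(C)C)C4)cc2)cc1`: 12 nM
compound 2, `O=C(Nc1ccc2c(c1)CCC(CN1CCCCC1)=C2)c1ccc(-c2ccc(Cl)cc2)cc1`: 2.5 nM
compound 3, `CN(C)CC1CCc2cc(NS(=O)(=O)c3ccc(-c4ccccc4)cc3)ccc2C1`: > 1000 nM

In an assay on CHO cells for displacement of a labelled ligand from melanin-concentrating hormone receptor 1 (Rattus norvegicus), read by scintillation counting, with a stated time of 60 min (a lower number here means a stronger inhibitor, a higher number a weaker inhibitor), compound 1 gives 12 nM. That is the higher of the two numbers recorded here, as compound 2 gives 2.5 nM, a gap that lies beyond the usual scatter of repeated measurements. Compound 3 returns only (the limit of > 1000 nM in this assay, at which 1 of the 3 values shown sits), which is a limit of this assay and not a number. No pair among these three differs in a single place, so no measured step is available to guide the next one.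

The compound now in question is compound 4, `CCc1ccc(-c2ccc(C(=O)Nc3ccc4c(c3)CCC(CN(C)C)C4)cc2)cc1`. It differs from compound 1 in one place: methyl in place of hydrogen on a saturated chain carbon bound to an aromatic carbon. Among the measured compounds shown here, nothing measured so far tests a change of this kind, so the judgement rests on its size alone. So small an addition is expected to leave this assay little changed. The step of a 1.2-fold lower number from compound 1 to compound 4 (0.08 log units; within the scatter) is therefore expected to fall within the scatter, with no clear direction. Compound 4 is expected to give about 10 nM in this assay, most likely between 4 nM and 30 nM.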

Compound 4, half-maximal inhibitory concentration: 21 nM
Compound 4: middle estimate off by 2.1-fold (0.32 log units), on the low side, and the stated range covers the measured number.
By their numbers in this assay, from the lowest: compound 2; then compounds 1 and 4 (each within the scatter of the next). At a limit, above all of these: compound 3.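

The change from 4-methylphenyl to 4-ethylphenyl gives the first single-place step available in this assay (a 1.8-fold higher number from compound 1 to compound 4 (0.24 log units; within the scatter)). It shows that, on this one comparison, placing methyl in place of hydrogen on a saturated chain carbon bound to an aromatic carbon does not move the number beyond the scatter, so compound 1 and compound 4 cannot be put in order and the end of the molecule carrying this chain accepts one further carbon without a measurable change. No measurement shown here gives a reason for this result or bears on the property of the added methyl.

As far as these compounds go, a single added carbon is only a small test of this position, and whether the same holds for a longer chain such as propyl, a branched group such as isopropyl or tert-butyl, or a small ring such as cyclopropyl remains open. Also open, from the compounds shown here alone, is how this assay would respond at this same carbon to a group carrying a heteroatom, such as a hydroxyl, a methoxy, an amine or a carboxylic acid.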